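The source may hold more compounds than are shown below. What is called first, only, known or untested is meant among the compounds shown, and "the series" means these compounds.

Compound 2, `COc1cc(N(Cc2nc3ccccc3[nH]2)C(=O)c2ccc(C)cc2)cc(OC)c1OC`, carries a 4-methylphenyl on the carbonyl carbon of the shared core. In a functional assay on PC-3 cells (Homo sapiens) for inhibition, read by MTT assay, with a stated time of 48 h (on this read-out higher numbers stand for weaker inhibition and lower numbers for stronger inhibition), compound 2 gives 42000 nM, the highest of the two numbers recorded so far. Its nearest neighbour is compound 1, `COc1cc(N(Cc2nc3ccccc3[nH]2)C(=O)c2ccc(Br)cc2)cc(OC)c1OC`, which differs only by a bromo in place of the methyl; in this assay compound 1 gives 19900 nM, and the step of a 2.1-fold higher number from compound 1 to compound 2 (0.32 log units; beyond the scatter) is modest but beyond the scatter.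

Compound 3, `COc1ccc(C(=O)N(Cc2nc3ccccc3[nH]2)c2cc(OC)c(OC)c(OC)c2)cc1OC`, is not yet measured. It differs from compound 2 by 3,4-dimethoxyphenyl in place of 4-methylphenyl on a carbonyl carbon. For the measured compounds named here, no measured step touches this change: the one step recorded, from bromo to methyl on an aromatic carbon, swaps two small groups and says nothing about replacing the 4-methylphenyl by a 3,4-dimethoxyphenyl with two hydrogen-bond acceptors. Both measured compounds sit in a narrow band, so the expectation for compound 3 rests on that band alone, with a direction that cannot be told.

Compound 3 is therefore expected to give roughly 35000 nM in this assay, within a range of 12000 nM to 100000 nM, which means an expected step of a 1.2-fold lower number from compound 2 to compound 3 (0.08 log units; within the scatter) that may well stay within the scatter.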

Compound 3, half-maximal inhibitory concentration: 34900 nM
Compound 3: middle estimate off by 1.0-fold (0.00 log units), on the high side; low and high end bracket the measured number.
By their numbers in this assay, from the lowest: compounds 1, 3 and 2 (each within the scatter of the next, the first and the last beyond it).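

In this assay, the swap of 4-methylphenyl for 3,4-dimethoxyphenyl on a carbonyl carbon gives a 1.2-fold lower number from compound 2 to compound 3 (0.08 log units; within the scatter), so this position accepts a larger group carrying hydrogen-bond acceptors with no change that stands out from the scatter, something the earlier swap of bromo and methyl could not show. Set against the 4-bromophenyl group, the same 3,4-dimethoxyphenyl gives a 1.8-fold higher number from compound 1 to compound 3 (0.24 log units; within the scatter), so compound 3 cannot be told apart from either compound 1 or compound 2, even though those two are separated from each other by a modest step beyond the scatter. Nothing in the material shown explains why these three aryl groups read so much alike.

Going by these compounds, all three compounds keep a substituted phenyl on this carbonyl carbon, so it remains open whether a group of another kind there, such as an amine, a carboxylic acid or a longer alkyl chain, would move the number further than these aryl swaps do. On these data alone, it is equally open whether changes elsewhere on the shared core would matter more than any change at this position.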